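Pentyl on the aryl ring: the step from compound 2 to compound 4

The source may hold more compounds than are shown below. What is called first, only, known or untested is meant among the compounds shown, and "the series" means these compounds.

Measured compounds:
compound 1 `CCCCCc1ccc(-c2cn([C@H]3C[C@H](CO)N(C)O3)nn2)cc1`, 3950 nM
compound 2 `CN1O[C@H](n2cc(-c3ccccc3)nn2)C[C@@H]1CO`, 6330 nM
compound 3 `CN1O[C@H](n2ccnn2)C[C@@H]1CO`, 6300 nM

Three compounds share one core and were read in a functional assay on FTC-133 cells (Homo sapiens) for cytotoxicity, read by MTT assay, with a stated time of 24 h; on this read-out higher numbers stand for weaker inhibition and lower numbers for stronger inhibition. Compound 2 gives 6330 nM, the highest of the three numbers, yet its nearest neighbour compound 3 gives 6300 nM and the furthest, compound 1, gives 3950 nM, both within the scatter of compound 2. Among the compounds with values here, the one step that differs in a single place, a 1.0-fold lower number from compound 2 to compound 3 (0.00 log units; within the scatter), shows that removing the phenyl altogether leaves the read-out unchanged. Compound 4 `CCCCCc1ccc(-c2cn([C@@H]3C[C@H](CO)N(C)O3)nn2)cc1` is not yet measured. It differs from compound 2 by pentyl in place of hydrogen on an aromatic carbon. Within the data shown here, no measured step adds a pentyl on this ring, and the only bearing step, the removal of phenyl, was flat. A step of no size beyond the scatter is therefore expected, a 1.4-fold lower number from compound 2 to compound 4 (0.15 log units; within the scatter). Compound 4 is estimated at 4500 nM, between 2000 nM and 10000 nM.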

Compound 4, half-maximal inhibitory concentration: 4490 nM
Estimate against measurement, compound 4: 1.0-fold (0.00 log units) above; the range from low to high includes it.
By their numbers in this assay, from the lowest: compounds 1, 4, 3 and 2 (each within the scatter of the next).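

In this assay, pentyl in place of hydrogen on an aromatic carbon, para to a large group, gives a 1.4-fold lower number from compound 2 to compound 4 (0.15 log units; within the scatter), so this position on the six-membered aromatic ring takes the pentyl with no step beyond the scatter. The earlier compounds shown here also offered no pair that could test configuration, and the stereocentre at the saturated ring carbon now gives a 1.1-fold higher number from compound 1 to compound 4 (0.06 log units; within the scatter), again within the scatter. That second step isolates the stereocentre, and the reading rests on one fact: the fact that compounds 1 and 4 differ only in the configuration as drawn

The compounds shown leave open whether a longer chain, an amine or a carboxylic acid in the pentyl's place would give a step beyond the scatter. Within the data shown here, the only pair that differs in configuration carries pentyl, so it also remains open whether the stereocentre would read the same with hydrogen at that position.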